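A few compounds are considered here, and "the series" means these few. Any claim that something is new, unique, unknown or untested is made for them only; others in the source may bear on it.

Compound 1, `Cc1cc(C(=O)Nc2c(F)cccc2F)nn1Cc1cc(Cl)ccc1OCc1ccccc1`, was tested in an assay on CHO-K1 cells for displacement of a labelled ligand from prostaglandin E2 receptor EP1 subtype (Homo sapiens) (a lower number here means a stronger inhibitor, a higher number a weaker inhibitor), and gave 10 nM. That number is level with compound 3 at the digits shown, and together they are the lowest of the three values, while compound 2 sits furthest away with a higher number.

Two other compounds share the core of compound 1. Compound 2, `Cc1cc(C(=O)NCc2ccccc2)nn1Cc1cc(Cl)ccc1OCc1ccccc1`, gives 39.8 nM in this assay, and compound 3, `Cc1cc(NC(=O)CC(C)(C)C)nn1Cc1cc(Cl)ccc1OCc1ccccc1`, gives 10 nM. The step from compound 1 to compound 2 is a 4.0-fold higher number from compound 1 to compound 2 (0.60 log units; beyond the scatter), and the step from compound 1 to compound 3 is no change at the digits printed from compound 1 to compound 3 (within the scatter).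

Compound 4, `Cc1cc(NC(=O)c2c(F)cccc2F)nn1Cc1cc(Cl)ccc1OCc1ccccc1`, has not yet been measured. It differs from compound 1 in one place: ((2,6-difluorophenyl)carbonyl)amino in place of (2,6-difluorophenyl)carbamoyl on an aromatic carbon. The step from compound 1 to compound 3 bears most directly on this change, since there the linking group was also turned around, together with a change of the outer group, and the number stayed the same. Compound 4 keeps the 2,6-difluorophenyl group of compound 1 and only turns the linker around, so no step beyond the scatter is expected. The estimate for compound 4 is 14 nM, within 4 nM to 50 nM, which means an expected step of a 1.4-fold higher number from compound 1 to compound 4 (0.15 log units; within the scatter).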

Compound 4, half-maximal inhibitory concentration: 12.6 nM
Estimate against measurement, compound 4: 1.1-fold (0.05 log units) above; measured number inside the range.
By their numbers in this assay, from the lowest: compounds 1, 3 and 4 (each within the scatter of the next); then compound 2.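

Turning the linker around while keeping the 2,6-difluorophenyl group gives a 1.3-fold higher number from compound 1 to compound 4 (0.10 log units; within the scatter) in this assay. This isolates what the earlier change from compound 1 to compound 3 mixed with a new outer group: on this aromatic carbon of the five-membered ring, the direction of the link alone does not move the number beyond the scatter. The outer group can now be read alone as well, since putting 2,6-difluorophenyl in place of neopentyl on the carbonyl carbon gives a 1.3-fold higher number from compound 3 to compound 4 (0.10 log units; within the scatter) with the linker held in its turned-around form, so these two outer groups are not told apart here. Against the benzylcarbamoyl group, the new compound shows a 3.2-fold lower number from compound 2 to compound 4 (0.50 log units; beyond the scatter) and so joins compound 1 and compound 3 in standing apart from compound 2.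

Still open, from the compounds shown here alone, is whether a (phenylacetyl)amino group, which would put a benzyl on the turned-around linker, would give a higher number as the benzylcarbamoyl group does, and whether a plain amine or a carboxylic acid on this carbon would hold the number at all. Nothing measured here explains why the number holds across these changes.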